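The source may report more compounds than this note shows. Statements on the series, on what has been measured and on what is new or still open speak of the compounds shown alone.

Of the compounds shown here, three built on one shared core have been measured in an assay for binding affinity to dual specificity mitogen-activated protein kinase kinase 4 (Homo sapiens), read by KINOMEscan, tested at 100 nM; a higher number here means a weaker effect of the compound at the concentration tested, a lower number a stronger effect. Compound 1 `CCCS(=O)(=O)Nc1ccc(F)c(C(=O)c2n[nH]c3ncc(-c4ccccc4Cl)cc23)c1F` gives 9.3%, compound 2 `CCCS(=O)(=O)Nc1ccc(F)c(C(=O)c2n[nH]c3ncc(-c4ccc(OC)cc4)cc23)c1F` gives 4.2%, and compound 3 `CCCS(=O)(=O)Nc1ccc(F)c(C(=O)c2n[nH]c3ncc(-c4ccc(C)c(C)c4)cc23)c1F` gives 20%. Compound 2 holds the lowest of the three numbers; its nearest neighbour is compound 1, with a number 5.1 percentage points lower from compound 1 to compound 2 (within the scatter), while the step of a number 15.8 percentage points higher from compound 2 to compound 3 (beyond the scatter) lies beyond the scatter, as does a number 10.7 percentage points higher from compound 1 to compound 3 (beyond the scatter).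

Compound 4 `CCCS(=O)(=O)Nc1ccc(F)c(C(=O)c2n[nH]c3ncc(-c4ccc(OC)cc4Cl)cc23)c1F` differs from compound 2 by chloro in place of hydrogen on an aromatic carbon. For the measured compounds named here, no measured step puts a chloro onto this ring on its own, but the step of a number 5.1 percentage points lower from compound 1 to compound 2 (within the scatter), in which 4-methoxyphenyl replaced 2-chlorophenyl, stayed within the scatter, so the chloro present in compound 1 did not set its number apart from that of compound 2. Compound 4 is therefore expected to show a number 1.8 percentage points higher from compound 2 to compound 4 (within the scatter), a step within the scatter. The estimate for compound 4 in this assay is 6%, ranging from 2% to 14%.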

Compound 4, a percentage reported as activity, at one concentration (the size of the read-out at that concentration, not a potency): 5.3%
Compound 4: middle estimate off by 0.7 percentage points, on the high side; the measured number falls inside the stated range.
By their numbers in this assay, from the lowest: compounds 2, 4 and 1 (each within the scatter of the next); then compound 3.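

In this assay, for the compounds shown here, chloro in place of hydrogen, ortho to a large group and meta to a methoxy group, is read on its own for the first time, as a number 1.1 percentage points higher from compound 2 to compound 4 (within the scatter) and so without setting compound 4 apart from compound 2. Methoxy in place of hydrogen on the same ring gives a number 4 percentage points lower from compound 1 to compound 4 (within the scatter) and likewise leaves the number within the scatter, whereas 2-chloro-4-methoxyphenyl in place of 3,4-dimethylphenyl gives a number 14.7 percentage points lower from compound 3 to compound 4 (beyond the scatter) and so leaves compound 3 apart from the other three. No measurement given here offers an explanation for these results.

On these data alone, it remains open whether an amine or a carboxylic acid on this ring would move the number beyond the scatter. Also open, as far as these compounds go, is whether chloro would leave the number of compound 3 unchanged as well.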